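Octanesulfonamide benzoic acids: benzophenone tail variation

The source may report more compounds than this note shows. Statements on the series, on what has been measured and on what is new or still open speak of the compounds shown alone.

Two members of the series have numbers in an assay on mitochondria (strain BALB/c) for inhibition of glycerol-3-phosphate acyltransferase 1, mitochondrial (Mus musculus), read by scintillation counting, with a stated time of 10 min; on this read-out lower numbers stand for stronger inhibition and higher numbers for weaker inhibition. Compound 1 `CCCCCCCCS(=O)(=O)Nc1cc(-c2cccc(F)c2)ccc1C(=O)O` gives 32600 nM in this assay. Compound 2 `CCCCCCCCS(=O)(=O)Nc1ccc(C(=O)c2ccc(CCCC)cc2)cc1C(=O)O` gives 31700 nM in this assay. For the measured compounds named here, the two numbers lie within the scatter of one another, so compound 2 cannot be separated from compound 1 on this read-out; no step between measured compounds is available to guide the next change.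

Compound 3 `CCCCCCCCS(=O)(=O)Nc1ccc(C(=O)c2ccc(-c3ccccc3)cc2)cc1C(=O)O` differs from compound 2 by phenyl in place of butyl on an aromatic carbon. Going by the values given here, with no comparable step measured, the expectation is that this change produces no step beyond the scatter in this assay, and the step from compound 2 to compound 3 is estimated as a 1.3-fold lower number from compound 2 to compound 3 (0.10 log units; within the scatter). On that basis compound 3 is expected to give about 25000 nM in this assay, with a range from 8000 nM to 80000 nM that also allows for a modest shift in either direction.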

Compound 3, half-maximal inhibitory concentration: 13000 nM
Beside the measured number, compound 3's estimate is 1.9-fold (0.28 log units) above it, within the range that was stated.
By their numbers in this assay, from the lowest: compound 3; then compounds 2 and 1 (each within the scatter of the next).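

In this assay this position is not indifferent to what it carries: phenyl in place of butyl on an aromatic carbon, para to a large group, gives a 2.4-fold lower number from compound 2 to compound 3 (0.39 log units; beyond the scatter). For the compounds shown here, this is the first readable step, and it favours the aromatic ring over the open chain, though the change brings in a ring and more heavy atoms at once, and the single pair cannot separate the two. Nothing at hand explains the step.

Open, on these data alone, is whether a cyclohexyl ring, a longer chain such as octyl, or a phenyl bearing an amine or a carboxylic acid at this place would lower the number further or raise it. Open too, as far as these compounds go, is whether the same replacement would give a comparable step on another core.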